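The compounds below may be only part of what the source reports. "The series", "measured", "known", "first", "only" and "open" are said of these compounds alone.

In an ADME assay on microsomes from liver (Homo sapiens) for metabolic stability, read by LC-MS, using NADPH, with a stated time of 10 min, tested at 10 uM (on this read-out lower numbers stand for a shorter-lived compound and higher numbers for a longer-lived compound), compound 2 `N#Cc1ccnc(Oc2nn(C3CCC3)c3ncnc(N)c23)c1` gives 2.35 h, the highest of the three numbers. Compound 1 `CC(C)(C)n1nc(Oc2cc(O)ccn2)c2c(N)ncnc21` gives 1.4 h, within the scatter of compound 2. Compound 3 `Nc1ncnc2c1c(Oc1cc(Cl)ccn1)nn2C1CCC1` gives 0.333 h; the step of a 7.1-fold lower number from compound 2 to compound 3 (0.85 log units; beyond the scatter) is the only step shown and does not touch the group changed here. Compound 4 `CC(C)(C)n1nc(Oc2cc(C#N)ccn2)c2c(N)ncnc21` differs from compound 2 by tert-butyl in place of cyclobutyl on an aromatic nitrogen. Within the data shown here, no measured step covers this change alone; compound 1 carries the same tert-butyl as compound 4, compound 2 the same cyano, and the values of compound 1 and compound 2 lie within the scatter of each other. Compound 4 is therefore expected to show no step beyond the scatter, a 1.2-fold lower number from compound 2 to compound 4 (0.07 log units; within the scatter). The half-life of compound 4 in this assay is estimated at 2 h, ranging from 1 h to 4 h.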

Compound 4, half-life: > 2.41 h
Compound 4: no number, only a limit; the forecaster's own chance of this, stated with the estimate: 5%; middle value at least 1.2-fold (0.08 log units) from the limit.
By their numbers in this assay, from the lowest: compound 3; then compounds 1 and 2 (each within the scatter of the next). At a limit, above all of these: compound 4.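

In this assay compound 4 reads only as a limit, not a number: the limit of > 2.41 h in this assay, at which 1 of the 4 values shown sits. Tert-butyl in place of cyclobutyl on the aromatic nitrogen, a change no earlier step covered, gives an at least 1.0-fold higher number from compound 2 to compound 4 (0.01 log units; that floor lies within the scatter), so no loss beyond the scatter appears at this position. Cyano in place of hydroxy on an aromatic carbon gives an at least 1.7-fold higher number from compound 1 to compound 4 (0.23 log units; that floor lies within the scatter), a second floor that sets no true size for the change.

On these data alone, the true size of both steps stays open. So does the effect of a longer chain on that nitrogen, or of an amine on that carbon.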